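Swapping a bromophenyl for a hydroxy-methoxyphenyl aryl hydrazone

The compounds below may be only part of what the source reports. "The series", "measured", "known", "first", "only" and "open" are said of these compounds alone.

Of the compounds shown here, three sharing one core have been tested in a functional assay on HT-29 cells (Homo sapiens) for cytotoxicity, read by MTT assay, with a stated time of 72 h; on this read-out lower numbers stand for stronger inhibition and higher numbers for weaker inhibition. Compound 1 `COc1ccc(OC)c(/C=N/NC(=O)Nc2ccc(Oc3ccnc(-c4nncn4CCN(C)C)c3)c(F)c2)c1` gives 2070 nM. Compound 2 `CN(C)CCn1cnnc1-c1cc(Oc2ccc(NC(=O)N/N=C/c3c(O)ccc4ccccc34)cc2F)ccn1` gives 670 nM. Among the compounds with values here, compound 3 `CN(C)CCn1cnnc1-c1cc(Oc2ccc(NC(=O)N/N=C/c3cccc(Br)c3)cc2F)ccn1` gives 380 nM, the lowest of the three numbers, though its gap to compound 2 lies within the scatter, so only the step of a 5.4-fold lower number from compound 1 to compound 3 (0.74 log units; beyond the scatter) stands out clearly.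

Compound 4 `COc1ccc(/C=N/NC(=O)Nc2ccc(Oc3ccnc(-c4nncn4CCN(C)C)c3)c(F)c2)cc1O` differs from compound 3 in one place: 3-hydroxy-4-methoxyphenyl in place of 3-bromophenyl on a carbon with a double bond to nitrogen. The most relevant comparison is the step of a 5.4-fold lower number from compound 1 to compound 3 (0.74 log units; beyond the scatter), where a phenyl carrying two methoxy groups gave a clearly weaker result than the bromophenyl. The step of a 3.1-fold lower number from compound 1 to compound 2 (0.49 log units; beyond the scatter) shows that an aromatic ring carrying a hydroxy group did somewhat better than the dimethoxyphenyl. Compound 4 carries both a hydroxy and a methoxy group, so a modest rise in the number is expected from compound 3 to compound 4, roughly a 2.9-fold higher number from compound 3 to compound 4 (0.46 log units; beyond the scatter). Compound 4 is therefore estimated at 1100 nM in this assay, with a range from 450 nM to 2700 nM.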

Compound 4, half-maximal inhibitory concentration: 960 nM
Compound 4: middle estimate off by 1.1-fold (0.06 log units), on the high side; the measured number falls inside the stated range.
By their numbers in this assay, from the lowest: compounds 3, 2 and 4 (each within the scatter of the next, the first and the last beyond it); then compound 1.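

At this place, on a carbon with a double bond to nitrogen, the 3-hydroxy-4-methoxyphenyl ring does not match the 3-bromophenyl ring in this assay (a 2.5-fold higher number from compound 3 to compound 4 (0.40 log units; beyond the scatter)), even though the bromophenyl has no hydrogen-bond donor or acceptor. The new ring cannot be told apart from the 2-hydroxynaphthalen-1-yl group, which also carries a hydroxy (a 1.4-fold higher number from compound 2 to compound 4 (0.16 log units; within the scatter)), yet it clearly improves on the 2,5-dimethoxyphenyl ring (a 2.2-fold lower number from compound 1 to compound 4 (0.33 log units; beyond the scatter)). Both hydroxy-bearing compounds therefore stand clear of compound 1, but compound 3 does too, with no hydroxy group at all, so a hydroxy is not needed for that gain.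

Going by these compounds, how an amine, a carboxylic acid or a chlorine on this ring would fare stays open. Nothing shown here explains these differences.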